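A few compounds are considered here, and "the series" means these few. Any claim that something is new, unique, unknown or untested is made for them only; others in the source may bear on it.

Two cyanine-type compounds have been examined in an assay for displacement of a labelled ligand from protein arginine N-methyltransferase 1 (Homo sapiens), read by scintillation proximity assay, with stated times of 5 min and 8 min, tested at 10 uM; a lower number here means a weaker effect, a higher number a stronger effect of the compound at the concentration tested. Compound 1, with the structure `CCCCN1/C(=C/C=C/C2=[N+](CCCC)c3ccc(Br)cc3C2(C)C)C(C)(C)c2cc(Br)ccc21`, gives 48% in this assay. Compound 2, with the structure `CCCCN1/C(=C/C=C/c2sc3ccccc3[n+]2CCCC)Sc2ccccc21`, gives 79% in this assay. Of these two numbers, that of compound 2 is the higher, and its gap to compound 1 lies beyond the scatter of repeated measurements, so compound 2 stands as the stronger of the pair on the numbers in hand. Within the data shown here, no pair of measured compounds differs in a single place, so the effect of a small change to compound 2 cannot be read from any precedent. Compound 3, with the structure `CCCCN1/C(=C/C(C)=C/c2sc3ccccc3[n+]2CCCC)Sc2ccccc21`, is the next compound to be tested; relative to compound 2 its difference is methyl in place of hydrogen on a double-bonded chain carbon bound to two double-bonded chain carbons. Nothing in the two measured numbers speaks to such a change. Compound 3 is therefore expected to give about 70% in this assay, within a range from 45% to 90%. The step implied by this estimate, a number 9 percentage points lower from compound 2 to compound 3 (within the scatter), is expected to be small and to lie within the usual scatter.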

Compound 3, a percentage reported as inhibition, at one concentration (the size of the read-out at that concentration, not a potency): 77%
The estimate for compound 3 lay 7 percentage points below the measured number, and the stated range covers the measured number.
By their numbers in this assay, from the lowest: compound 1; then compounds 3 and 2 (each within the scatter of the next).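

Among these compounds, the methyl in place of hydrogen on a double-bonded chain carbon bound to two double-bonded chain carbons provides the first comparison in this assay of compounds that differ in one place, with a number 2 percentage points lower from compound 2 to compound 3 (within the scatter). Among the compounds shown here, at this position, then, the added methyl leaves the read-out at the tested concentration indistinguishable from that of the hydrogen-bearing compound, so compound 3 and compound 2 stand together where no precedent for any change existed before. Nothing measured here offers an explanation for this outcome.

On these data alone, whether the same position would accept an ethyl group, a longer chain, an amine or a carboxylic acid remains open, as does whether methyl would have the same outcome on the core of compound 1. Each number is also the size of the read-out at one concentration, so whether compound 2 and compound 3 would differ in the strength of their effect at any other concentration remains an open question.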